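Swapping Methyl for Hydroxy on a Weakly Active Compound

The compounds below may be only part of what the source reports. "The series", "measured", "known", "first", "only" and "open" are said of these compounds alone.

Measured compounds:
- compound 1 `CN(C)/C=C/C(=O)c1nn(-c2ccccc2)c(-c2ccccc2)c1C#N`: 98000 nM
- compound 2 `Cc1nnc(-c2nn(-c3ccccc3)c(-c3ccccc3)c2C#N)c2cn(-c3ccccc3)nc12`: 92000 nM

In a functional assay on IGROV-1 cells (Homo sapiens) for inhibition, read by sulforhodamine B assay, with a stated time of 48 h (on this read-out lower numbers stand for stronger inhibition of growth and higher numbers for weaker inhibition of growth), compound 2 gives 92000 nM, within the usual scatter of compound 1 at 98000 nM. Compound 3 `N#Cc1c(-c2nnc(O)c3nn(-c4ccccc4)cc23)nn(-c2ccccc2)c1-c1ccccc1` carries hydroxy in place of methyl on an aromatic carbon. The measured compounds differ in more than one place, so no measured step sizes this change. No step beyond the scatter is expected, in either direction, and the expected change is a 1.2-fold lower number from compound 2 to compound 3 (0.06 log units; within the scatter). For compound 3 the estimated value is 80000 nM, with an expected range of 30000 nM to 130000 nM.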

Compound 3, concentration for 50% growth inhibition: 92200 nM
The estimate for compound 3 lay 1.2-fold (0.06 log units) below the measured number, and the stated range covers the measured number.
By their numbers in this assay, from the lowest: compounds 2, 3 and 1 (each within the scatter of the next).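

For the compounds shown here, with hydroxy in place of methyl on this aromatic carbon, next to the ring nitrogen, this assay gives a 1.0-fold higher number from compound 2 to compound 3 (0.00 log units; within the scatter) and so provides the first direct reading of a change at this position. The hydrogen-bond donor and acceptor counted for hydroxy come with no step beyond the scatter in this pair. Nothing available explains this flat result.

On these data alone, whether an amine or a longer chain at this position would shift the number remains open. So does whether this swap would behave the same way on a compound with a different core.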